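One Ring Carbon Redrawn: Expected Half-Life of Compound 3

A few compounds are considered here, and "the series" means these few. Any claim that something is new, unique, unknown or untested is made for them only; others in the source may bear on it.

Measured so far:
compound 1 `COC[C@H]1C[C@@H](C(=O)NC[C@H]2CCCO2)CN(Cc2nc(-c3ccccc3)oc2C)C1` gives 0.403 h
compound 2 `Cc1oc(-c2ccccc2)nc1CN1CCC[C@@H](C(=O)NC[C@@H]2CCCO2)C1` gives 0.235 h

Both numbers come from an in vitro ADME assay on microsomes from liver (Homo sapiens) for metabolic stability; a higher number here means that the compound lasts longer, a lower number that the compound disappears faster. Compound 2 has the lower of the two numbers, but its gap to compound 1 lies within the scatter of repeated measurements, so on these data the two compounds cannot be told apart.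

Compound 3 `Cc1oc(-c2ccccc2)nc1CN1CCC[C@@H](C(=O)NC[C@H]2CCCO2)C1` has not yet been measured. Its change from compound 2 is small: the two compounds have the same atoms and bonds and differ only in configuration as drawn: 1 of 2 stereo elements differ; a stereocentre at a saturated ring carbon is drawn S in compound 2 and R in compound 3. Among the compounds with values here, no step between two measured compounds of this kind is available to lean on, so the expectation is that the step from compound 2 to compound 3 stays within the scatter, with no clear direction. Compound 2, at 0.235 h, serves as the anchor. The estimated step is a 1.2-fold higher number from compound 2 to compound 3 (0.08 log units; within the scatter). Compound 3 is therefore expected to give 0.28 h in this assay, with a range from 0.12 h to 0.65 h.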

Compound 3, half-life: 0.193 h
Beside the measured number, compound 3's estimate is 1.5-fold (0.16 log units) above it, and the stated range covers the measured number.
By their numbers in this assay, from the lowest: compounds 3, 2 and 1 (each within the scatter of the next, the first and the last beyond it).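

In this assay, redrawing the saturated ring carbon from S to R gives a 1.2-fold lower number from compound 2 to compound 3 (0.09 log units; within the scatter), so the configuration at this carbon makes no readable difference here. This pair gives a clean test of that single stereocentre: the fact that compounds 2 and 3 differ only in the configuration as drawn. Within the data shown here, the second new comparison concerns a different change, hydrogen in place of methoxymethyl on a saturated ring carbon, and gives a 2.1-fold lower number from compound 1 to compound 3 (0.32 log units; beyond the scatter), a modest step that lies just beyond the scatter and is the first readable structure-linked difference in this small set.

The compounds shown leave open whether the half-life would respond to other groups on that saturated ring carbon, such as hydroxymethyl, an ethoxymethyl chain or an amine. They also leave open whether the stereocentre would matter with methoxymethyl in place.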